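This account rests on a few compounds, and the source may have more. Where it says the series, first, only, none or still open, it means among the compounds named here.

Measured compounds in a functional assay on A549 cells (Homo sapiens) for antiproliferative activity, read by MTT assay, with a stated time of 24 h; a higher number here means a weaker inhibitor, a lower number a stronger inhibitor:

compound 1, `O=c1[nH]cc(S(=O)(=O)Nc2ccccc2-c2cn(-c3ccccc3Cl)nn2)c(=O)[nH]1`, gives 2740 nM
compound 2, `O=c1[nH]cc(S(=O)(=O)Nc2ccccc2-c2cn(-c3cccc(Cl)c3)nn2)c(=O)[nH]1`, gives 2340 nM
compound 3, `O=c1[nH]cc(S(=O)(=O)Nc2cccc(-c3cn(-c4ccccc4Cl)nn3)c2)c(=O)[nH]1`, gives 2730 nM

All three measured compounds share a sulfonamide-linked bicyclic core carrying a triazole that bears a chlorophenyl group on an aromatic nitrogen, and in this assay their numbers sit close together. Compound 2 differs from compound 1 by 3-chlorophenyl in place of 2-chlorophenyl on an aromatic nitrogen, and that change produced a 1.2-fold lower number from compound 1 to compound 2 (0.07 log units; within the scatter), so within this pair moving the chlorine around the ring did nothing that can be told apart from repeat-measurement noise. Compound 3 uses a differently connected core from compound 1; the difference between the two cores is not broken down here, and the two values of compound 3 and compound 1 stand essentially level in this assay.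

Compound 4, `O=c1[nH]cc(S(=O)(=O)Nc2cccc(-c3cn(-c4cccc(Cl)c4)nn3)c2)c(=O)[nH]1`, is not yet measured. It differs from compound 3 by 3-chlorophenyl in place of 2-chlorophenyl on an aromatic nitrogen, the same change that turns compound 1 into compound 2, at a place described in identical words for both pairs. Among the measured compounds shown here, the only precedent for this change is the step from compound 1 to compound 2, and on that basis the step of a 1.1-fold lower number from compound 3 to compound 4 (0.06 log units; within the scatter) is expected to be small, within the scatter of this assay. For the measured compounds named here, compound 4 is therefore estimated to give 2400 nM in this assay, with a plausible range of 1400 nM to 4200 nM; the range is widened somewhat because only one pair, compound 1 to compound 2, supports the expectation with a 1.2-fold lower number from compound 1 to compound 2 (0.07 log units; within the scatter).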

Compound 4, half-maximal inhibitory concentration: 2430 nM
Estimate against measurement, compound 4: 1.0-fold (0.01 log units) below; the range from low to high includes it.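

In this assay, 3-chlorophenyl in place of 2-chlorophenyl on an aromatic nitrogen gives a 1.1-fold lower number from compound 3 to compound 4 (0.05 log units; within the scatter), so on the core of compound 3 this change again produces nothing that can be told apart from repeat-measurement noise. The change reads the same on both cores, with no detectable difference between the two steps: the same change on two cores in this assay, a 1.2-fold lower number (0.07 log units; within the scatter) from compound 1 to compound 2 and a 1.1-fold lower number (0.05 log units; within the scatter) from compound 3 to compound 4, 1.0-fold (0.02 log units) apart, within the scatter of two such steps. Among the compounds shown here, this shows only that the swap between these two chlorophenyl groups stays silent on two cores in one cell assay; since neither step leaves the scatter, it is a weak test of transfer, and it does not show that a change with a larger effect would carry from one core to the other, or that the swap would stay silent in another assay.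

The compounds shown all carry a chlorophenyl group on the aromatic nitrogen, so it remains open whether a methoxy group, an amine or a carboxylic acid in place of the chlorine would move the number in this assay beyond the scatter. Also open, from the compounds shown here alone, is whether a longer alkyl chain in place of the chlorophenyl group would do so, and whether any such effect would match on the two cores.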